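The compounds below may be only part of what the source reports. "The series", "measured", "known", "first", "only" and "open" are said of these compounds alone.

Compound 1 (`O=C(C1CC1)[C@H]1C[C@@H]2CNC[C@@H](C2)C1`): in an assay on CHO cells for agonist activity at Neuronal acetylcholine receptor; alpha3/beta4 (Homo sapiens), read by FLIPR and calcium flux (on this read-out lower numbers stand for smaller maximal responses and higher numbers for larger maximal responses), compound 1 gives 10%.
Compound 2 (`CCCNC(=O)[C@H]1C[C@@H]2CNC[C@@H](C2)C1`): in this assay compound 2 gives 24%.

For the measured compounds named here, compound 2 stands highest of the two numbers so far, its nearest neighbour being compound 1, whose value lies lower by a margin beyond the scatter. Going by the values given here, the only measured step is a number 14 percentage points higher from compound 1 to compound 2 (beyond the scatter), and it is the sole guide to how the carbonyl substituent of this shared core affects the maximal response.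

Compound 3 (`CC(C)NC(=O)[C@H]1C[C@@H]2CNC[C@@H](C2)C1`) keeps the amide of compound 2 and differs from it only on the amide-type nitrogen: isopropyl in place of propyl on an amide-type nitrogen. Among the compounds with values here, this change is a rearrangement of the same atoms, not an exchange of one group class for another, and no measured pair shows such a rearrangement. The step from compound 1 to compound 2 replaced a ring with an alkylamino group, so it bears only loosely on the move from propyl to isopropyl. Compound 3 is therefore expected to sit close to compound 2, with a step of about a number 2 percentage points lower from compound 2 to compound 3 (within the scatter), likely within the scatter. The estimate for compound 3 in this assay is 22%, ranging from 8% to 40%.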

Compound 3, largest response reached (Emax), in percent of the reference or control that the assay uses: 25%
The estimate for compound 3 lay 3 percentage points below the measured number; the measured number falls inside the stated range.
By their numbers in this assay, from the lowest: compound 1; then compounds 2 and 3 (each within the scatter of the next).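

In this assay, isopropyl in place of propyl on an amide-type nitrogen gives a number 1 percentage points higher from compound 2 to compound 3 (within the scatter) and so the two chains, which hold the same atoms joined differently, cannot be told apart on this read-out. Isopropylamino in place of cyclopropyl on a carbonyl carbon gives a number 15 percentage points higher from compound 1 to compound 3 (beyond the scatter) and so repeats, with a second alkylamino group, the kind of step that propylamino gave in the same place. Both amides on the shared core therefore stand clear of compound 1, while nothing shown explains this difference or the closeness of the two amides.

The compounds shown leave open whether a longer chain such as hexyl, or a phenyl ring, on the amide-type nitrogen would give a maximal response like those of compound 2 and compound 3 or a different one. From the compounds shown here alone, it also remains open whether cyclopropylamino on the carbonyl carbon would read like compound 1 or like compound 3, a comparison that would separate the cyclopropyl ring from the amide nitrogen.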